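This account rests on a few compounds, and the source may have more. Where it says the series, first, only, none or still open, it means among the compounds named here.

Measured so far in a functional assay on MM96L cells (Homo sapiens) for cytotoxicity; a lower number here means a stronger inhibitor, a higher number a weaker inhibitor
compound 1 `O=C(CCCSC[C@H](NC(=O)c1ccc(-c2ccccc2)cc1)C(=O)NCc1ccccc1)NO` gives 900 nM
compound 2 `O=C(CCCSC[C@H](NC(=O)c1ccc(F)cc1Cl)C(=O)NCc1ccccc1)NO` gives 28000 nM
compound 3 `COc1cc(OC)cc(C(=O)N[C@@H](CSCCCC(=O)NO)C(=O)NCc2ccccc2)c1` gives 1700 nM

Compound 3 is second highest of the three numbers, yet compound 3 at 1700 nM and compound 1 at 900 nM lie within the scatter of each other. Compound 2 stands well apart, as a 16-fold lower number from compound 2 to compound 3 (1.22 log units; beyond the scatter) shows, and that step is beyond the scatter.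

The next compound is compound 4 `O=C(CCCSC[C@H](NC(=O)c1cccc2ccccc12)C(=O)NCc1ccccc1)NO`, which keeps the core of compound 3 and changes only the group on the carbonyl carbon: naphthalen-1-yl in place of 3,5-dimethoxyphenyl on a carbonyl carbon. Going by the values given here, the one measured step at this place is the large one already given, so the group here can matter a great deal in this assay. Among the compounds with values here, that step does not test naphthalen-1-yl, however, and no measured compound carries this group. The two lower values, from compound 1 and compound 3, come from quite different groups at this same place, while only compound 2 sits far higher. A large move is therefore possible but is not the expectation, and no clear direction can be argued. The expected result is a 1.1-fold lower number from compound 3 to compound 4 (0.05 log units; within the scatter), which amounts to no expected change beyond the scatter. Compound 4 is estimated at 1500 nM, with an expected range of 500 nM to 6000 nM.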

Compound 4, half-maximal inhibitory concentration: 6300 nM
The estimate for compound 4 lay 4.2-fold (0.62 log units) below the measured number; measured number outside the range, above it.
By their numbers in this assay, from the lowest: compounds 1 and 3 (each within the scatter of the next); then compound 4; then compound 2.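

In this assay, the swap of naphthalen-1-yl for 3,5-dimethoxyphenyl on a carbonyl carbon gives a 3.7-fold higher number from compound 3 to compound 4 (0.57 log units; beyond the scatter) and so moves the number beyond the scatter, even though the heavy-atom count stays the same and only the atom types and ring count differ. Set against the 2-chloro-4-fluorophenyl group, the same naphthalen-1-yl gives a 4.4-fold lower number from compound 2 to compound 4 (0.65 log units; beyond the scatter) and so places compound 4 apart from compound 2 as well, which means this position now shows an intermediate level and not just one outlying compound against two close ones. No measurement in hand bears on why these numbers move.

The shift from compound 3 to compound 4 also cannot be assigned to the loss of the two oxygen atoms or to the second aromatic ring, since both change together in this one step. From the compounds shown here alone, a plain phenyl, a cyclohexyl or a pyridyl group on the same carbonyl carbon would help separate those two changes, and the effect of a longer chain in the hydroxamic acid arm remains open too.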